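The compounds below may be only part of what the source reports. "The series", "measured", "known", "first", "only" and "open" are said of these compounds alone.

Measured so far:
compound 1 `CCCc1ccc(Nc2cccc3c2C(=O)N(C2CCC(=O)NC2=O)C3=O)cc1` with 23%
compound 2 `CC(C)(C)c1ccc(Nc2cccc3c2C(=O)N(C2CCC(=O)NC2=O)C3=O)cc1` with 36%

Among the compounds with values here, in an assay on FRT-Jurkat cells for inhibition of nuclear factor NF-kappa-B complex (Homo sapiens), read by flow cytometry, with a stated time of 24 h, tested at 10 uM (a higher number here means more inhibition at the concentration tested (going by the name of the read-out), a lower number less inhibition), compound 2 stands highest of the two numbers; its nearest neighbour is compound 1, and the only measured step is a number 13 percentage points higher from compound 1 to compound 2 (beyond the scatter). Compound 3 `Cc1ccccc1Nc1cccc2c1C(=O)N(C1CCC(=O)NC1=O)C2=O` is not yet measured. The change is 2-methylphenyl in place of 4-(tert-butyl)phenyl on a nitrogen on an aromatic ring. Within the data shown here, the one step that bears on it ran the other way, a larger alkyl group on the phenyl giving more inhibition, so removing the tert-butyl is expected to cost inhibition in this assay, a step of about a number 14 percentage points lower from compound 2 to compound 3 (beyond the scatter). Compound 3 is therefore expected near 22%, with a range of 5% to 40%.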

Compound 3, a percentage reported as inhibition, at one concentration (the size of the read-out at that concentration, not a potency): 7%
Compound 3: middle estimate off by 15 percentage points, on the high side, and the stated range covers the measured number.
By their numbers in this assay, from the lowest: compound 3; then compound 1; then compound 2.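

In this assay, 2-methylphenyl on the nitrogen gives a number 29 percentage points lower from compound 2 to compound 3 (beyond the scatter) and, against 4-propylphenyl, a number 16 percentage points lower from compound 1 to compound 3 (beyond the scatter) at this same place. The aryl group here therefore moves the read-out further than the exchange of propyl for tert-butyl did, and 2-methylphenyl sits lowest of the three, with both steps beyond the scatter. Nothing available accounts for this drop.

The compounds shown do not separate the size of the alkyl group from where it sits on the phenyl ring. From the compounds shown here alone, how an amine, a carboxylic acid or a chain longer than propyl on that ring would read stays open.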